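Hydroxymethyl to hydroxy on a chlorinated benzylamide partner

A few compounds are considered here, and "the series" means these few. Any claim that something is new, unique, unknown or untested is made for them only; others in the source may bear on it.

Compound 1 `Cc1ccsc1C(=CCCN(C)C(CCO)C(=O)NCc1ccccc1)c1sccc1C` gives 5.71 in a physicochemical assay for lipophilicity, read by HPLC; a higher number here means a more lipophilic compound, a lower number a more polar compound. Compound 2 `Cc1ccsc1C(=CCCN(C)C(CO)C(=O)NCc1ccccc1)c1sccc1C` gives 6.26 in this assay, and compound 3 `Cc1ccsc1C(=CCCN(C)C(CCO)C(=O)NCc1ccc(Cl)cc1)c1sccc1C` gives 6.38. The change from compound 1 to compound 2 is hydroxy in place of hydroxymethyl on a saturated chain carbon, two bonds along the chain from an amine nitrogen and a carbonyl carbon; the step was a number 0.55 log units higher from compound 1 to compound 2 (beyond the scatter). The cores of compound 1 and compound 3 differ by chloro in place of hydrogen on an aromatic carbon, a step of a number 0.67 log units higher from compound 1 to compound 3 (beyond the scatter). Compound 3 and compound 2 differ by a gap within the scatter.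

Compound 4 `Cc1ccsc1C(=CCCN(C)C(CO)C(=O)NCc1ccc(Cl)cc1)c1sccc1C` is not yet measured. Relative to compound 3 it carries hydroxy in place of hydroxymethyl on a saturated chain carbon, two bonds along the chain from an amine nitrogen and a carbonyl carbon, the same change as from compound 1 to compound 2, at the same place. The step from compound 3 to compound 4 is expected to be a number 0.55 log units higher from compound 3 to compound 4 (beyond the scatter) in this assay, resting on the single earlier occurrence of this change, a number 0.55 log units higher from compound 1 to compound 2 (beyond the scatter), with no evidence on whether the chloro-bearing core alters it. Compound 4 is therefore estimated at 6.93 in this assay, between 6.5 and 7.35.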

Compound 4, partition coefficient: 6.47
Estimate against measurement, compound 4: 0.46 log units above; measured number below the stated range.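

The change at the saturated chain carbon, read in this assay as hydroxy in place of hydroxymethyl, gave a number 0.55 log units higher from compound 1 to compound 2 (beyond the scatter) on the core without chloro but a number 0.09 log units higher from compound 3 to compound 4 (within the scatter) on the chloro-bearing core, so a step beyond the scatter on one core did not carry over to the other. Read the other way, chloro in place of hydrogen gave a number 0.67 log units higher from compound 1 to compound 3 (beyond the scatter) but then a number 0.21 log units higher from compound 2 to compound 4 (within the scatter) in the second pair, so the two changes do not simply add across these four compounds. This shows that the step depends on its partner in this one set, but with one pair per core it does not show how general that is, and nothing available explains the difference.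

Open, from the compounds shown here alone, is whether the same dependence holds with an amine or a carboxylic acid at that saturated chain carbon, or with a longer chain ending in hydroxy. Also open, going by these compounds, is whether bromo or methoxy in place of chloro would give the same pattern.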